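A few compounds are considered here, and "the series" means these few. Any claim that something is new, unique, unknown or untested is made for them only; others in the source may bear on it.

Measured compounds:
compound 1, `Cc1ccccc1N(C)C(=O)c1ccc(-c2ccc(OS(N)(=O)=O)c(Cl)c2)o1`, 25%
compound 2, `Cc1ccccc1N(C)C(=O)c1ccc(-c2ccc(OS(N)(=O)=O)c(F)c2)o1`, 18%
compound 3, `Cc1ccccc1N(C)C(=O)c1ccc(-c2ccc(OS(N)(=O)=O)cc2Cl)o1`, 13%

The three compounds were tested in an assay on cytosol from placenta for inhibition of 17-beta-hydroxysteroid dehydrogenase type 1 (Homo sapiens), read by HPLC, with a stated time of 10 min, tested at 1 uM, in the presence of a further agent that is not named here; on this read-out higher numbers stand for more inhibition at the one concentration tested (going by the name of the read-out) and lower numbers for less inhibition. Compound 1 and compound 2 share a core and differ in one place, described by fluoro in place of chloro on an aromatic carbon. This change gave a number 7 percentage points lower from compound 1 to compound 2 (within the scatter), so the two results are not told apart by this read-out. Compound 3 has the same atoms as compound 1, joined differently; the difference between the two cores is not broken down here. In this assay compound 3 gives 13%, and this stands within the scatter of the result for compound 2, while its gap to compound 1 lies beyond the scatter.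

Compound 4, `Cc1ccccc1N(C)C(=O)c1ccc(-c2ccc(OS(N)(=O)=O)cc2F)o1`, has not yet been measured. It differs from compound 3 by fluoro in place of chloro on an aromatic carbon. Among the compounds with values here, this is the same kind of change as the one from compound 1 to compound 2, but at a different place: there the fluoro sat ortho to a sulfamoyloxy group and meta to a large group, here it sits ortho to a large group and meta to a sulfamoyloxy group.

For compound 4 an expected step of a number 5 percentage points lower from compound 3 to compound 4 (within the scatter) is set beside the earlier one, resting on the small and within-scatter step a number 7 percentage points lower from compound 1 to compound 2 (within the scatter). Compound 4 is estimated to give about 8% in this assay, with a likely range from 0% to 20%.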

Compound 4, a percentage reported as inhibition, at one concentration (the size of the read-out at that concentration, not a potency): 19%
Estimate against measurement, compound 4: 11 percentage points below; measured number inside the range.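

In this assay, fluoro in place of chloro on an aromatic carbon, here ortho to a large group and meta to a sulfamoyloxy group, gave a number 6 percentage points higher from compound 3 to compound 4 (within the scatter), so the read-out does not tell this pair apart. Although the step on this core and the earlier step on the core of compound 1 carry opposite signs, the two cannot be separated from each other: the same change on two cores in this assay, a number 7 percentage points lower (within the scatter) from compound 1 to compound 2 and a number 6 percentage points higher (within the scatter) from compound 3 to compound 4, 13 percentage points apart, within the scatter of two such steps What this shows is that the exchange of chloro for fluoro stayed within the scatter on both cores, while it does not show that the change has a size or direction that carries over from one core to the other, nor that it has no effect, since single readings at one concentration can resolve only larger steps.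

The compounds shown leave open whether another group on the same aromatic carbon, such as methoxy, nitrile or trifluoromethyl, would shift the number beyond the scatter on either core. They also leave open what an amine or a hydroxyl in place of the sulfamoyloxy group would do, and how these compounds compare in potency, which a percentage at one concentration does not give.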